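The source may hold more compounds than are shown below. What is called first, only, known or untested is meant among the compounds shown, and "the series" means these compounds.

Measured in a functional assay on HeLa cells (Homo sapiens) for cytotoxicity, read by MTT assay, with a stated time of 48 h; on this read-out lower numbers stand for stronger inhibition and higher numbers for weaker inhibition:

- compound 1 `Cc1n[nH]c2c1C(c1ccc(N(C)C)cc1)C(C(=O)NNC(N)=S)=C(N)N2`: 6260 nM
- compound 2 `Cc1n[nH]c2c1C(c1ccc(N(C)C)cc1)C(C(=O)n1ncc(C#N)c1N)=C(N)N2`: 60200 nM
- compound 3 `Cc1n[nH]c2c1C(c1ccc(N(C)C)cc1)C=C(N)N2`: 27400 nM

Compound 1 has the lowest number of the three, so it is the strongest inhibitor in this small set. The next compound, compound 4 `Cc1n[nH]c2c1C(c1ccc(N(C)C)cc1)C(C(=O)N/N=C1/C(=O)Nc3ccccc31)=C(N)N2`, keeps the core of compound 1 and differs on an amide-type nitrogen whose other neighbour is the carbonyl carbon: a group of 11 heavy atoms (8 carbon, 2 nitrogen, 1 oxygen; one five-membered non-aromatic ring with 1 hetero atom, one six-membered aromatic ring of carbon only) in place of a group of 4 heavy atoms (1 carbon, 2 nitrogen, 1 sulfur; no ring), on an amide-type nitrogen. A much larger group with two rings therefore replaces a small chain with no ring.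

Among the compounds with values here, two measured steps bear on this change. Replacing the end of the chain with a different ring group gave a 9.6-fold higher number from compound 1 to compound 2 (0.98 log units; beyond the scatter), and removing the whole chain gave a 4.4-fold higher number from compound 1 to compound 3 (0.64 log units; beyond the scatter). Both changes moved the number up by a modest amount, and both lie beyond the scatter. Neither introduces the group found in compound 4, so they offer only a rough guide. A modest rise in this assay is expected, probably no larger than the first of these steps, although a value close to that of compound 1 remains possible.

Compound 4 is estimated at 14000 nM, with an expected range from 3500 nM to 55000 nM. This estimate means a 2.2-fold higher number from compound 1 to compound 4 (0.35 log units; beyond the scatter).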

Compound 4, half-maximal inhibitory concentration: 52900 nM
Compound 4: middle estimate off by 3.8-fold (0.58 log units), on the low side; the measured number falls inside the stated range.
By their numbers in this assay, from the lowest: compound 1; then compounds 3, 4 and 2 (each within the scatter of the next, the first and the last beyond it).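

Swapping the end of the chain on the amide-type nitrogen for the larger two-ring group, while keeping the carbonyl and that nitrogen in place, gave an 8.5-fold higher number from compound 1 to compound 4 (0.93 log units; beyond the scatter) in this assay, so keeping this part of the chain does not by itself preserve the number of compound 1. The value for compound 4 (52900 nM) also lies within the scatter of that for compound 3 (27400 nM), which has no chain at all, so in this assay the two-ring group shows no measurable gain over a plain hydrogen on the double-bonded ring carbon, whereas the small sulfur-bearing chain of compound 1 does. No measurement at hand explains why the number rises with this change.

The compounds shown leave open whether the lower number of compound 1 depends on its sulfur or simply on a small group without a ring. The same chain with oxygen in place of sulfur, or a plain acetyl group on the amide-type nitrogen, would help to separate these two readings.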